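From Ester to Enone on a Shared Core

A few compounds are considered here, and "the series" means these few. Any claim that something is new, unique, unknown or untested is made for them only; others in the source may bear on it.

Compound 1, `O=C(CSC(=S)N[C@H]1CCOC1=O)Nc1ccc(Cl)cc1`: 76900 nM
Compound 2, `Cc1ccc(NC(=O)CSC(=S)N[C@H]2CCOC2=O)cc1`: 44300 nM
Compound 3, `CCOC(=O)c1ccc(NC(=O)CSC(=S)N[C@H]2CCOC2=O)cc1`: 21700 nM

Three measured compounds share one core and differ only in the group on an aromatic carbon. In a functional assay on MGC-803 cells (Homo sapiens) for cytotoxicity, read by MTT assay, with a stated time of 72 h (on this read-out higher numbers stand for weaker inhibition and lower numbers for stronger inhibition), compound 1 gives 76900 nM, compound 2 gives 44300 nM and compound 3 gives 21700 nM. Compound 3 thus stands lowest of the three, and both of its steps to the others lie beyond the scatter: a 3.5-fold lower number from compound 1 to compound 3 (0.55 log units; beyond the scatter) and a 2.0-fold lower number from compound 2 to compound 3 (0.31 log units; beyond the scatter). The remaining step, a 1.7-fold lower number from compound 1 to compound 2 (0.24 log units; within the scatter), stays within the scatter.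

Compound 4, `O=C(CSC(=S)N[C@H]1CCOC1=O)Nc1ccc(C(=O)/C=C/c2cccc(Cl)c2)cc1`, has not yet been measured in this assay. It differs from compound 3 in one place: 2-(3-chlorophenyl)ethenyl in place of ethoxy on a carbonyl carbon. Within the data shown here, none of the measured steps touches a carbonyl carbon, so they bear on this change only loosely; what they show is that each replacement on the aromatic carbon that enlarged the substituent lowered the number modestly, as in a 2.0-fold lower number from compound 2 to compound 3 (0.31 log units; beyond the scatter). The change to compound 4 enlarges the substituent far more than any measured step did. A modest further lowering is expected, a 2.7-fold lower number from compound 3 to compound 4 (0.43 log units; beyond the scatter), though with wide uncertainty. Compound 4 is therefore estimated to give 8000 nM in this assay, within a range from 1500 nM to 30000 nM.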

Compound 4, half-maximal inhibitory concentration: 15600 nM
For compound 4 the middle estimate is 2.0-fold (0.29 log units) below the measured one; the range from low to high includes it.
By their numbers in this assay, from the lowest: compounds 4 and 3 (each within the scatter of the next); then compounds 2 and 1 (each within the scatter of the next).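

In this assay, the exchange of ethoxy for 2-(3-chlorophenyl)ethenyl on the carbonyl carbon gives a 1.4-fold lower number from compound 3 to compound 4 (0.14 log units; within the scatter), so a group of 9 heavy atoms with an aromatic ring and a double bond takes the place of one of 3 heavy atoms, and the two numbers cannot be told apart. The earlier steps shown here all lay on the aromatic carbon, where a 2.0-fold lower number from compound 2 to compound 3 (0.31 log units; beyond the scatter) and a 3.5-fold lower number from compound 1 to compound 3 (0.55 log units; beyond the scatter), and the link they suggested between a larger substituent and a lower number does not appear at this carbonyl carbon, which shows that this site accepts a far larger group with no reading beyond the scatter. Nothing at hand gives a reason for this result.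

The compounds shown leave open whether the chloro on the ring or the double bond has any bearing on the number, which 2-phenylethenyl or 2-(3-chlorophenyl)ethyl on the same carbonyl carbon would address. Among these compounds, they also leave open how this position reads with an amine or a carboxylic acid in place of ethoxy, since only two groups on the carbonyl carbon are compared here.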